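Working notes: adding a methyl to compound 3

The source may hold more compounds than are shown below. What is called first, only, known or untested is meant among the compounds shown, and "the series" means these compounds.

Measured in an ADME assay on MRC5 cells (Homo sapiens) for cytotoxicity, read by fluorescence, with a stated time of 72 h; a higher number here means a weaker inhibitor, a lower number a stronger inhibitor (each value is a limit of the assay and not a number)

compound 1 `CC1(COc2ccc(-c3ccc(F)cc3)cc2)Cn2cc([N+](=O)[O-])nc2O1` gives > 64000 nM (a limit)
compound 2 `C[C@]1(COc2ccc(OC(F)(F)F)cc2)Cn2cc([N+](=O)[O-])nc2O1` gives > 64000 nM (a limit)
compound 3 `O=[N+]([O-])c1cn2c(n1)OC(COCc1ccc(OC(F)(F)F)cc1)C2` gives > 64000 nM (a limit)

Compound 3 reads > 64000 nM (a limit, so its true position in this assay is not a number). Among the measured compounds shown here, the whole set shows the same picture, and the limit of > 64000 nM in this assay, at which 3 of the 3 values shown sit, is the only evidence on these compounds.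

Compound 4 `CC1(COCc2ccc(OC(F)(F)F)cc2)Cn2cc([N+](=O)[O-])nc2O1` is the next compound to be read. Its structure departs from that of compound 3 at one place methyl in place of hydrogen on a saturated ring carbon (methyl in place of hydrogen on a saturated ring carbon, next to the ring oxygen). Compound 1 and compound 2 also carry a methyl on that ring carbon, and neither comes off the limit.

For the measured compounds named here, no step between measured compounds is available, so the size of this change cannot be read directly. No step beyond the scatter is expected, in either direction, and a further limit reading is the likeliest result. The estimated step of a number no higher from compound 3 to compound 4 (the limit leaves the size open) is expected to be negligible. For compound 4 the estimated value is 64000 nM (expected range 32000 nM to 64000 nM) in this assay when it is measured.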

Compound 4, half-maximal inhibitory concentration: 60000 nM
The estimate for compound 4 lay 1.1-fold (0.03 log units) above the measured number; the range from low to high includes it.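

In this assay, methyl in place of hydrogen on a saturated ring carbon, next to the ring oxygen, gives an at least 1.0-fold lower number from compound 3 to compound 4 (0.02 log units; that floor lies within the scatter), so this change has a floor for its size and no measured size. Among the compounds shown here, compound 4, at 60000 nM, supplies the first reading in this set that is a number and not a limit, which gives this position a fixed point that the earlier compounds could not provide. Compound 3, at > 64000 nM, remains a limit of the assay and not a number, so the data do not show whether the methyl leaves the reading unchanged or lowers it by more than the floor.

On these data alone, whether this change has any real effect on the read-out therefore stays open, and the set offers little room to test it, as most of its readings sit at one limit: the limit of > 64000 nM in this assay, at which 3 of the 4 values shown sit. Also open, as far as these compounds go, is how the reading would respond to a larger or charged group on the same ring carbon, such as an ethyl group, an amine or a carboxylic acid in place of the methyl.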